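The source may report more compounds than this note shows. Statements on the series, on what has been measured and on what is new or still open speak of the compounds shown alone.

In a functional assay on MKN-74 cells (Homo sapiens) for antiproliferative activity, with a stated time of 24 h (on this read-out higher numbers stand for weaker inhibition and lower numbers for stronger inhibition), compound 2 `CSc1ccccc1NC(=S)N1CCc2c(sc(NC(=O)c3ccccc3Cl)c2C(N)=O)C1` gives 13800 nM, the higher of the two numbers recorded, though its nearest neighbour, compound 1 `Cc1ccccc1NC(=S)N1CCc2c(sc(NC(=O)c3ccccc3Cl)c2C(N)=O)C1` with 11700 nM in this assay, lies within the scatter: a 1.2-fold higher number from compound 1 to compound 2 (0.07 log units; within the scatter). Compound 3 `NC(=O)c1c(NC(=O)c2ccccc2Cl)sc2c1CCN(C(=S)Nc1ccc(C(F)(F)F)cc1)C2` differs from compound 2 by 4-(trifluoromethyl)phenyl in place of 2-(methylsulfanyl)phenyl on an amide-type nitrogen. For the measured compounds named here, the single measured step, an exchange of the substituent on the same phenyl ring, stayed within the scatter; no measured step covers a 4-(trifluoromethyl)phenyl group, so nothing recorded points to a change beyond the scatter in this assay. Compound 3 is therefore expected at 12000 nM (range 4000 nM to 36000 nM), the estimated step being a 1.2-fold lower number from compound 2 to compound 3 (0.06 log units; within the scatter).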

Compound 3, half-maximal inhibitory concentration: 7090 nM
Compound 3: the middle estimate sits 1.7-fold (0.23 log units) above what was measured; the measured number falls inside the stated range.
By their numbers in this assay, from the lowest: compounds 3, 1 and 2 (each within the scatter of the next).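

In this assay the 4-(trifluoromethyl)phenyl group on the amide-type nitrogen was read against both earlier groups, giving a 1.9-fold lower number from compound 2 to compound 3 (0.29 log units; within the scatter) and a 1.7-fold lower number from compound 1 to compound 3 (0.22 log units; within the scatter). At this position, 2-methylphenyl, 2-(methylsulfanyl)phenyl and 4-(trifluoromethyl)phenyl therefore show no step beyond the scatter, now including an exchange of the whole aryl group rather than only its substituent. No supporting data offer an explanation for these steps. Open, as far as these compounds go, is whether a non-aromatic group on this nitrogen, such as cyclohexyl or an aminoethyl chain, or a carboxylic acid on the phenyl ring, would give a step beyond the scatter.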